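The source may hold more compounds than are shown below. What is called first, only, known or untested is meant among the compounds shown, and "the series" means these compounds.

Among the measured compounds shown here, compound 1 `CCn1c(C(=O)NCCN(C)C)ccc1C(CC)(CC)c1ccc(OCCC(O)(CC)CC)c(C)c1` gives the lower of the two numbers so far in an assay on cells for agonist activity at vitamin D3 receptor (Homo sapiens), with a stated time of 96 h (on this read-out higher numbers stand for an effect only at larger amounts of compound and lower numbers for an effect already at smaller amounts), namely 82 nM. Compound 2 `C#CCCOC(=O)c1ccc(C(CC)(CC)c2ccc(OCCC(O)(CC)CC)c(C)c2)n1CC` gives 6030 nM in this assay, so the step of a 74-fold higher number from compound 1 to compound 2 (1.87 log units; beyond the scatter) is large and runs toward weaker effect; it exchanges the whole (2-(dimethylamino)ethyl)amino group on the carbonyl carbon for (but-3-yn-1-yl)oxy.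

Compound 3 `CCOc1ccc(NC(=O)c2ccc(C(CC)(CC)c3ccc(OCCC(O)(CC)CC)c(C)c3)n2CC)cc1` differs from compound 1 by 4-ethoxyphenyl in place of 2-(dimethylamino)ethyl on an amide-type nitrogen, so the amide-type nitrogen on the carbonyl carbon is kept and only the chain on it is exchanged for a ring. For the measured compounds named here, the one measured step bears on this position, but it removed the amide-type nitrogen altogether, so it is a weaker guide here. A step in the same weakening direction but clearly smaller is expected, roughly a 4.9-fold higher number from compound 1 to compound 3 (0.69 log units; beyond the scatter). Compound 3 is therefore estimated at 400 nM in this assay, with a range from 80 nM to 2500 nM.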

Compound 3, half-maximal effective concentration: 1630 nM
Beside the measured number, compound 3's estimate is 4.1-fold (0.61 log units) below it; the range from low to high includes it.
By their numbers in this assay, from the lowest: compound 1; then compound 3; then compound 2.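

Keeping the amide-type nitrogen on the carbonyl carbon is not enough to hold the low number: with 4-ethoxyphenyl in place of 2-(dimethylamino)ethyl on that nitrogen, this assay shows a 20-fold higher number from compound 1 to compound 3 (1.30 log units; beyond the scatter), so what sits on the nitrogen matters too. Putting (4-ethoxyphenyl)amino in place of (but-3-yn-1-yl)oxy on the carbonyl carbon gives a 3.7-fold lower number from compound 2 to compound 3 (0.57 log units; beyond the scatter), a modest recovery that falls well short of the level of compound 1. Nothing available here explains why the numbers move this way.

From the compounds shown here alone, it remains open whether the amine in the 2-(dimethylamino)ethyl chain or the open chain itself favours compound 1. A plain butyl chain on the same amide-type nitrogen, or a phenyl ring carrying a dimethylamino group in place of the ethoxy group, would help separate these two possibilities.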